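The source may hold more compounds than are shown below. What is called first, only, known or untested is meant among the compounds shown, and "the series" means these compounds.

Compound 1 `CCC(CC)Nc1nc(C)nc2c(-c3ccc(OC)nc3C)c(C)nn12`: 3.1 nM
Compound 2 `CCC(CC)Nc1nc(C)nc2c(-c3c(C)cc(N(C)C)nc3C)c(C)nn12`: 25.6 nM

In an assay on cell membranes for displacement of a labelled ligand from corticotropin-releasing factor receptor 1 (Rattus norvegicus) (a lower number here means a stronger inhibitor, a higher number a weaker inhibitor), compound 1 gives 3.1 nM, the lowest of the two measured numbers; compound 2 gives 25.6 nM, a higher number by a gap beyond the usual scatter. Compound 3 `CCN(CC)c1nc(C)nc2c(-c3ccc(OC)nc3C)c(C)nn12` differs from compound 1 in one place: diethylamino in place of (pentan-3-yl)amino on an aromatic carbon. For the measured compounds named here, no measured pair shows this exchange, so nothing here fixes its size. For compound 3 a modest rise in number is expected, an estimated step of a 2.6-fold higher number from compound 1 to compound 3 (0.41 log units; beyond the scatter) in this assay, with wide uncertainty. Compound 3 is therefore expected to give 8 nM, in a range from 2 nM to 40 nM.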

Compound 3, half-maximal inhibitory concentration: 12 nM
For compound 3 the middle estimate is 1.5-fold (0.18 log units) below the measured one; low and high end bracket the measured number.
By their numbers in this assay, from the lowest: compound 1; then compound 3; then compound 2.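

In this assay, the exchange on the aromatic carbon between two ring nitrogen atoms gives a 3.9-fold higher number from compound 1 to compound 3 (0.59 log units; beyond the scatter) and so shows that this position responds to the amine attached there. The step is modest, even though diethylamino has 0 hydrogen-bond donors where (pentan-3-yl)amino has 1. Nothing at hand explains its size.

The compounds shown cannot separate the lost donor from the changed chain, a question that ethylamino or dipropylamino at this position could address. Going by these compounds, whether the same exchange gives a similar step on the core of compound 2 also remains open.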